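Naphthyl Ether Gives Way to Nitrophenyl in a Thiosemicarbazone Series

The source may report more compounds than this note shows. Statements on the series, on what has been measured and on what is new or still open speak of the compounds shown alone.

Compound 1 `S=C(N/N=C/c1ccc(Oc2ccc(Cl)cc2)cc1)Nc1ccccc1`: 5.52
Compound 2 `S=C(N/N=C/c1ccc(Oc2ccc3ccccc3c2)cc1)Nc1ccc(Cl)cc1`: 6.96
Compound 3 `Cc1cc(Oc2ccc(/C=N/NC(=S)Nc3ccc(F)cc3)cc2)ccc1Cl`: 6.07

Three thiosemicarbazones have been measured in a physicochemical assay for lipophilicity, in phosphate buffer, measured as octanol-water partition, with a stated time of 24 h; on this read-out lower numbers stand for lower lipophilicity and higher numbers for higher lipophilicity. Compound 1 gives 5.52, compound 2 gives 6.96 and compound 3 gives 6.07. Compound 2 stands highest of the three numbers in this assay. Its nearest neighbour is compound 3, which lies lower by a margin beyond the scatter, and its furthest is compound 1, lower by a still wider margin, also beyond the scatter. No pair among these three differs in a single place, so no step between measured compounds is available to guide the next one.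

Compound 4 `O=[N+]([O-])c1ccc(Oc2ccc(/C=N/NC(=S)Nc3ccc(Cl)cc3)cc2)cc1` has not yet been measured in this assay. It differs from compound 2 as follows: 4-nitrophenyl in place of naphthalen-2-yl on an oxygen on an aromatic ring.

Among the compounds with values here, no measured step covers this kind of change. Compound 4 is expected to fall clearly in this assay, with a step from compound 2 estimated at a number 1.56 log units lower from compound 2 to compound 4 (beyond the scatter), a move well beyond the scatter and downward. On that basis compound 4 is expected to give about 5.4 in this assay, within a range from 4.8 to 6.1.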

Compound 4, partition coefficient: 5.52
For compound 4 the middle estimate is 0.12 log units below the measured one; the range from low to high includes it.
By their numbers in this assay, from the lowest: compounds 1 and 4 (each within the scatter of the next); then compound 3; then compound 2.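

On an oxygen on an aromatic ring, exchanging naphthalen-2-yl for 4-nitrophenyl gives a number 1.44 log units lower from compound 2 to compound 4 (beyond the scatter) in this assay. Within the data shown here, this is the first single-place comparison, and it shows that the read-out responds strongly to the group at this position while the rest of the structure stays the same, something the earlier compounds, none of them differing in one place, could not show. The exchange removes 2 six-membered aromatic rings of carbon only and brings in one, along with 2 hydrogen-bond acceptors, but nothing at hand ties the step to either of these differences or to anything else.

A single step cannot separate the loss of a ring from the arrival of the nitro group, and a plain phenyl or an aminophenyl group on the same oxygen would help to tell those two apart. Going by these compounds, it also remains open whether an exchange of this kind would give a step of similar size on the cores of compound 1 and compound 3.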